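A few compounds are considered here, and "the series" means these few. Any claim that something is new, unique, unknown or untested is made for them only; others in the source may bear on it.

Measured so far:
Compound 1 `COc1cc2c(cc1N1C[C@@H](C)N[C@@H](C)C1)N(C(=O)c1ccc(-c3ccc(-c4noc(C)n4)cc3C)cc1)CC2`: 0 in an assay on isolated protein with 5-hydroxytryptamine receptor 1B (Homo sapiens) as the target; a higher number here means a larger maximal response, a lower number a smaller maximal response
Compound 2 `COc1cc2c(cc1N1C[C@@H](C)N(C)[C@@H](C)C1)N(C(=O)c1ccc(-c3cccc(C)n3)c3ccccc13)CC2`: 0.3 in this assay
Compound 3 `COc1cc2c(cc1N1C[C@@H](C)N(C)[C@@H](C)C1)N(C(=O)c1ccc(-c3ccccc3C)cc1)CC2`: 0 in this assay

Compound 2 gives the highest of the three numbers in this assay. Compound 1 gives a lower number and compound 3 likewise a lower number, both beyond the scatter, so compound 2 stands apart as the only one of the three with a measurable maximal response.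

Compound 4 `COc1cc2c(cc1N1CCN(C)CC1)N(C(=O)c1ccc(-c3cccc(C)n3)c3ccccc13)CC2` has not yet been measured in this assay. It differs from compound 2 in one place: 4-methylpiperazin-1-yl in place of 3,4,5-trimethylpiperazin-1-yl on an aromatic carbon. The group that leaves carries 2 defined stereocentres; the one that enters carries none, and it is smaller by two carbon atoms as counted above.

Within the data shown here, no step between measured compounds separates this change from anything else, so there is nothing in the measured numbers to set its size. Compound 2 already sits low, and the two neighbours sit at zero. The step from compound 2 to compound 4 is expected to be small and downward, a number 0.10 lower from compound 2 to compound 4 (within the scatter), within the scatter. Compound 4 is therefore estimated to give 0.2, with a range from 0 to 0.4.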

Compound 4, intrinsic activity: the largest response reached, as a fraction of the reference agonist's: 0.9
For compound 4 the middle estimate is 0.70 below the measured one; measured number outside the range, above it.
By their numbers in this assay, from the lowest: compounds 1 and 3 (each within the scatter of the next); then compound 2; then compound 4.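

In this assay, putting 4-methylpiperazin-1-yl in place of 3,4,5-trimethylpiperazin-1-yl on this aromatic carbon, ortho to a methoxy group, gives a number 0.60 higher from compound 2 to compound 4 (beyond the scatter). Among these compounds, this is the first step measured at this position, and it shows that the maximal response depends strongly on this substituent when the rest of the molecule stays the same. The data offer no explanation for the size of this step.

Going by these compounds, it remains open whether the same replacement would raise the response on the different acyl groups of compound 1 and compound 3, or whether both ring methyl groups must go. Nor do the compounds shown reveal how a 3,4-dimethylpiperazin-1-yl, a 4-ethylpiperazin-1-yl or a morpholin-4-yl group would behave on this carbon.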